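The source may hold more compounds than are shown below. What is called first, only, known or untested is meant among the compounds shown, and "the series" means these compounds.

Measured in a functional assay on U-251 cells (Homo sapiens) for antiproliferative activity, read by MTT assay, with a stated time of 72 h; a lower number here means a stronger inhibitor, a higher number a weaker inhibitor:
Compound 1 `O=C1C=C(N2CCN(c3ccccc3Cl)CC2)C(=O)c2ccccc21`: 30800 nM
Compound 2 `O=C1C=C(N2CCN(c3ccccc3Cl)CC2)C(=O)c2c(O)cccc21`: 8000 nM

Compound 2 holds the lower of these two numbers, which makes it the stronger inhibitor of the pair, and its gap to compound 1 lies beyond the scatter. Compound 3 `Cc1ccccc1N1CCN(C2=CC(=O)c3cccc(O)c3C2=O)CC1` keeps everything in compound 2 except one group: methyl in place of chloro on an aromatic carbon. This puts methyl in place of chloro on an aromatic carbon, ortho to a large group, so that 2-chlorophenyl becomes 2-methylphenyl.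

Among the compounds with values here, only one measured step is available as a guide: a 3.9-fold lower number from compound 1 to compound 2 (0.59 log units; beyond the scatter). That modest step came from hydroxy in place of hydrogen, a different change, so it bears on this one only indirectly. Within the data shown here, it shows that a single small substitution on this scaffold can shift the number in this assay, but no measured pair tests chloro against methyl. As far as these compounds go, a step beyond the scatter is therefore not expected, and either direction remains open.

The estimate for compound 3 is 9000 nM, with an expected range of 3500 nM to 23000 nM. The expected change is a 1.1-fold higher number from compound 2 to compound 3 (0.05 log units; within the scatter).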

Compound 3, half-maximal inhibitory concentration: 10200 nM
Compound 3: the middle estimate sits 1.1-fold (0.05 log units) below what was measured; the range from low to high includes it.
By their numbers in this assay, from the lowest: compounds 2 and 3 (each within the scatter of the next); then compound 1.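

In this assay, replacing chloro with methyl gives a 1.3-fold higher number from compound 2 to compound 3 (0.11 log units; within the scatter), so at this place, on an aromatic carbon ortho to a large group, the assay does not tell these two groups apart. Within the data shown here, the earlier step changed a different place, hydroxy for hydrogen, and showed that the number can respond to a small substitution on this scaffold; this step is the first reading from the 2-chlorophenyl end of the molecule, and here a swap of one heavy atom for another leaves the two compounds within the scatter of each other. Nothing available explains why these two groups read alike.

The compounds shown leave open whether a group of another kind at this same place, such as methoxy, an amine or a carboxylic acid, would move the number beyond the scatter, or whether this place accepts those as well. They also leave open whether chloro and methyl would still read alike on the core of compound 1, which lacks the hydroxy group.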